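The source may hold more compounds than are shown below. What is called first, only, known or untested is meant among the compounds shown, and "the series" means these compounds.

Measured compounds:
- compound 1, `CC(C)=CCC/C(C)=C/CC/C(C)=C/CC[C@@H]1[C@@]2(C)CC/C(=N\OCc3cn(-c4cccc(Br)c4)nn3)C(C)(C)[C@@H]2CC[C@@]1(C)O`: 14600 nM
- compound 2, `CC(C)=CCC/C(C)=C/CC/C(C)=C/CC[C@@H]1[C@@]2(C)C/C(=C\c3ccc(OCc4cn(-c5ccccc5)nn4)cc3)C(=O)C(C)(C)[C@@H]2CC[C@@]1(C)O`: 21000 nM

The two measured compounds share a terpenoid core and differ in how the triazole-bearing arm is attached. In a functional assay on DU-145 cells (Homo sapiens) for cytotoxicity, read by MTT assay, with a stated time of 48 h (a lower number here means a stronger inhibitor, a higher number a weaker inhibitor), compound 1 gives 14600 nM. In this assay compound 2 gives 21000 nM. These two numbers lie within the usual scatter of each other, so the data show no real difference between compound 1 and compound 2.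

Compound 3, `CC(C)=CCC/C(C)=C/CC/C(C)=C/CC[C@@H]1[C@@]2(C)C/C(=C\c3ccc(OCc4cn(-c5cccc([N+](=O)[O-])c5)nn4)cc3)C(=O)C(C)(C)[C@@H]2CC[C@@]1(C)O`, is still to be measured. It is derived from compound 2 by a single change: nitro in place of hydrogen on an aromatic carbon. Among the measured compounds shown here, with only two measured compounds and no step between them that isolates a comparable change, there is no direct precedent to weigh the effect of this substitution. The expectation is therefore a step of a 1.4-fold lower number from compound 2 to compound 3 (0.15 log units; within the scatter), a small move that does not clearly exceed the scatter, leaning toward a somewhat lower number. On this basis compound 3 is estimated at 15000 nM, with a plausible range from 5000 nM to 45000 nM.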

Compound 3, half-maximal inhibitory concentration: 46400 nM
The estimate for compound 3 lay 3.1-fold (0.49 log units) below the measured number; the measured number lies above the stated range.
By their numbers in this assay, from the lowest: compounds 1 and 2 (each within the scatter of the next); then compound 3.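

Among the compounds shown here, the change from phenyl to 3-nitrophenyl is the only comparison here that isolates a single place, and in this assay it gives a 2.2-fold higher number from compound 2 to compound 3 (0.34 log units; beyond the scatter), a modest step that lies beyond the scatter. It shows that this aromatic carbon, meta to a large group, is not indifferent to substitution: putting nitro in place of hydrogen there goes with a weaker inhibitor, something compound 1 and compound 2 could not show, since they differ in how the triazole-bearing arm is attached. Nothing in the data shown gives a reason for this step.

As far as these compounds go, what stays open is whether the higher number belongs to nitro itself or would come with other groups on the same aromatic carbon, such as an amine, a methoxy group or a carboxylic acid. From the compounds shown here alone, it is also open whether the same change would have a comparable effect in the differently attached arm of compound 1, since a single step on one arm cannot settle that.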